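Hydrazone acid series, rat whole-organism inhibition notes

The compounds below may be only part of what the source reports. "The series", "measured", "known", "first", "only" and "open" are said of these compounds alone.

Measured so far:
compound 1, `CC1CCn2c(ncc(C(=O)O)c2=O)/C1=N/Nc1ccccc1`: > 320 umol/kg
compound 2, `CC1CC/C(=N\Nc2ccccc2Br)c2ncc(C(=O)O)c(=O)n21`: > 320 umol/kg

In a functional assay on the whole organism for inhibition, with Rattus norvegicus as the target (on this read-out higher numbers stand for an effect only at larger amounts of compound and lower numbers for an effect already at smaller amounts), compound 1 gives only a limit, > 320 umol/kg. In this assay compound 2 likewise gives only a limit, > 320 umol/kg. Both thus stand at the limit of > 320 umol/kg in this assay, at which 2 of the 2 values shown sit, so no number for compound 2 is known and no ranking is possible. Compound 3, `CC1CC/C(=N\Nc2ccc(O)cc2)c2ncc(C(=O)O)c(=O)n21`, carries 4-hydroxyphenyl in place of 2-bromophenyl on an amine nitrogen. Going by the values given here, no step between measured compounds exists, so no size can be drawn from the data. The step from compound 2 to compound 3 is expected to be a number no higher from compound 2 to compound 3 (the limit leaves the size open), none beyond the scatter, with a limit again the likeliest report. Compound 3 is expected at 320 umol/kg, in the range 120 umol/kg to 1000 umol/kg.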

Compound 3, dose for 50% inhibition: > 100 umol/kg
Compound 3 gave a limit, no number; the forecaster's own chance of this, stated with the estimate: 85%; the middle value lies beyond the limit too.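

Compound 2 and compound 3 are both reported only as limits, and the step between them cannot be read. On these data alone, whether 4-hydroxyphenyl or 2-bromophenyl on the amine nitrogen gives an effect at smaller amounts of compound remains open.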